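The compounds below may be only part of what the source reports. "The series", "measured", "known", "first", "only" and "open" are said of these compounds alone.

Compound 2 `CC(C)(C)OC(=O)NCCS(=O)(=O)NC(=O)c1ccc(Nc2nc(NC3(c4ccc(Cl)cc4)CC3)nc(OCC(F)(F)F)n2)cc1` stands lowest of the three compounds measured in a physicochemical assay for permeability, using PAMPA, at pH 7.4; a lower number here means that the compound crosses the layer more slowly, a higher number that the compound crosses the layer faster: compound 2 gives 111 nm/s. Compound 1 `O=C(NS(=O)(=O)c1ccc(F)cc1)c1ccc(Nc2nc(NC3(c4ccc(Cl)cc4)CC3)nc(OCC(F)(F)F)n2)cc1` gives 193 nm/s, and the step of a 1.7-fold lower number from compound 1 to compound 2 (0.24 log units; within the scatter) is within the scatter, so these two are not told apart. Going by the values given here, compound 3 `CC(C)(C)CNCCS(=O)(=O)NC(=O)c1ccc(Nc2nc(NC3(c4ccc(Cl)cc4)CC3)nc(OCC(F)(F)F)n2)cc1` gives 651 nm/s; the steps of a 3.4-fold higher number from compound 1 to compound 3 (0.53 log units; beyond the scatter) and a 5.9-fold higher number from compound 2 to compound 3 (0.77 log units; beyond the scatter) are the only changes in this small set that move the number beyond the scatter.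

Compound 4 `CC(C)NC(=O)NCCS(=O)(=O)NC(=O)c1ccc(Nc2nc(NC3(c4ccc(Cl)cc4)CC3)nc(OCC(F)(F)F)n2)cc1` differs from compound 2 by isopropylamino in place of tert-butoxy on a carbonyl carbon. Among the compounds with values here, no measured step touches the carbonyl carbon in this way. The nearest comparison is a 5.9-fold higher number from compound 2 to compound 3 (0.77 log units; beyond the scatter), where the whole tert-butoxycarbonyl group leaves the amine nitrogen, a larger change than exchanging tert-butoxy for isopropylamino while the carbonyl stays. The change is therefore expected to give a small step, if anything downward: a 1.5-fold lower number from compound 2 to compound 4 (0.17 log units; within the scatter). For compound 4 the value in this assay is estimated at 75 nm/s, with a range from 35 nm/s to 160 nm/s.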

Compound 4, apparent permeability: 45 nm/s
Compound 4: the middle estimate sits 1.7-fold (0.22 log units) above what was measured; the measured number falls inside the stated range.
By their numbers in this assay, from the lowest: compound 4; then compounds 2 and 1 (each within the scatter of the next); then compound 3.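

Isopropylamino in place of tert-butoxy on a carbonyl carbon gives a 2.5-fold lower number from compound 2 to compound 4 (0.39 log units; beyond the scatter) in this assay and so shows that this position can move the number downward while the carbonyl stays on the amine nitrogen. The spread at that nitrogen also widens, with a 14-fold lower number from compound 3 to compound 4 (1.16 log units; beyond the scatter) as the largest step in the set, and a 4.3-fold lower number from compound 1 to compound 4 (0.63 log units; beyond the scatter) places compound 4 alone at the low end, beyond the scatter of all three others. Nothing on hand accounts for the direction of this step.

The compounds shown leave open whether the drop follows the nitrogen on the carbonyl carbon or the shape of the group it carries. A dimethylamino or a cyclohexylamino group on the same carbonyl carbon would begin to separate these two readings.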